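The source may report more compounds than this note shows. Statements on the series, on what has been measured and on what is new or still open speak of the compounds shown alone.

In a functional assay on MDA-MB-231 cells (Homo sapiens) for cytotoxicity, read by MTT assay, with a stated time of 72 h (a lower number here means a stronger inhibitor, a higher number a weaker inhibitor), compound 1 `O=C(CN1CCN(c2nnc(Cc3ccccc3)c3ccccc23)CC1)Nc1ccc(F)c(C(F)(F)F)c1` gives 760 nM, and compound 2 `O=C(CN1CCN(c2nnc(Cc3ccccc3)c3ccccc23)CC1)Nc1cc(C(F)(F)F)ccc1Cl` gives 19500 nM, the higher of the two numbers. Compound 3 `O=C(CN1CCN(c2nnc(Cc3ccccc3)c3ccccc23)CC1)Nc1cccc(Br)c1` differs from compound 2 by 3-bromophenyl in place of 2-chloro-5-(trifluoromethyl)phenyl on an amide-type nitrogen. Among the measured compounds shown here, the one measured step bearing on this, a 26-fold higher number from compound 1 to compound 2 (1.41 log units; beyond the scatter), is large and also concerns the group on that nitrogen. On that single precedent, a sizeable move to a lower number is expected, a 6.5-fold lower number from compound 2 to compound 3 (0.81 log units; beyond the scatter). For compound 3 the estimated value is 3000 nM, with an expected range of 600 nM to 15000 nM.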

Compound 3, half-maximal inhibitory concentration: 3880 nM
Estimate against measurement, compound 3: 1.3-fold (0.11 log units) below; the range from low to high includes it.
By their numbers in this assay, from the lowest: compound 1; then compound 3; then compound 2.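

The change to 3-bromophenyl gives a 5.0-fold lower number from compound 2 to compound 3 (0.70 log units; beyond the scatter) and a 5.1-fold higher number from compound 1 to compound 3 (0.71 log units; beyond the scatter) on the same amide-type nitrogen, so this position separates all three compounds by more than the scatter. Compound 1 and compound 2 both carry a trifluoromethyl group yet lie on either side of compound 3, so that group's presence alone does not set the order. No measured evidence accounts for these differences. The compounds shown leave open how a ring bearing an amine or a carboxylic acid would read at this nitrogen.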